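Swapping the amine linker for an ether in compound 2

The source may report more compounds than this note shows. Statements on the series, on what has been measured and on what is new or still open speak of the compounds shown alone.

Measured so far:
- compound 1, `Cc1c(Nc2ccc(C#N)cc2Cl)ncnc1OC1C2COCC1CN(C(=O)OC(C)(C)C)C2`: 28 nM; 140 nM (2 entries)
- compound 2, `Cc1c(Nc2ccc(C#N)cc2Cl)ncnc1OC1C2COCC1CN(C(=O)OC1(C)CC1)C2`: 33 nM
- compound 3, `COc1c(Nc2ccc(C#N)cc2Cl)ncnc1OC1C2COCC1CN(C(=O)OC1(C)CC1)C2`: 43 nM

In a functional assay on HEK293 cells for agonist activity at Glucose-dependent insulinotropic receptor (Mus musculus), read by fluorescence and cAMP accumulation, with a stated time of 30 min (a lower number here means that less compound is needed, a higher number that more compound is needed for the effect), compound 2 gives 33 nM. Compound 3 sits near it, the step of a 1.3-fold higher number from compound 2 to compound 3 (0.11 log units; within the scatter) falling inside the scatter, and compound 1 has two entries that spread widely (the several entries of compound 1 in this assay, 28 nM; 140 nM (2 entries)). Compound 4, `Cc1c(Oc2ccc(C#N)cc2Cl)ncnc1OC1C2COCC1CN(C(=O)OC1(C)CC1)C2`, is not yet measured. It differs from compound 2 in one place: 2-chloro-4-cyanophenoxy in place of (2-chloro-4-cyanophenyl)amino on an aromatic carbon. Among the measured compounds shown here, no measured step changes this linker, so the only guide is the shared core carrying the same substituents. A moderate loss of potency is expected, and the step of a 3.0-fold higher number from compound 2 to compound 4 (0.48 log units; beyond the scatter) is an estimate. Compound 4 is expected to give about 100 nM, within 30 nM to 400 nM.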

Compound 4, half-maximal effective concentration: 128 nM
Compound 4: the middle estimate sits 1.3-fold (0.11 log units) below what was measured; low and high end bracket the measured number.
By their numbers in this assay, from the lowest: compounds 2 and 3 (each within the scatter of the next); then compound 4.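

The linker atom on the shared core matters, unlike the methoxy for methyl change, which stayed within the scatter. In this assay, replacing the amino link with the oxygen link, which removes that group's hydrogen-bond donor, gives a 3.9-fold higher number from compound 2 to compound 4 (0.59 log units; beyond the scatter). This modest step needs caution, since repeat entries for one compound can differ widely: the several entries of compound 1 in this assay, 28 nM; 140 nM (2 entries)

The compounds shown do not separate the loss of the donor from other effects of the swap. A sulfur or methylene linker could help, as could the oxygen link paired with the methoxy group of compound 3.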